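This account rests on a few compounds, and the source may have more. Where it says the series, first, only, none or still open, it means among the compounds named here.

In a functional assay on K562 cells (Homo sapiens) for inhibition (a higher number here means a weaker inhibitor, a lower number a stronger inhibitor), compound 1 `CCC(=O)OC1C(C(O)CO)OC2OC(C)(C)OC21` gives 2400000 nM and compound 2 `CC1(C)OC2OC(C(O)CO)C(OC(=O)CC(c3ccccc3)c3ccccc3)C2O1` gives 500000 nM. Among the compounds with values here, compound 2 therefore holds the lower of the only two numbers, and the gap between them lies beyond the scatter. Compound 3 `CC(CC(=O)OC1C(C(O)CO)OC2OC(C)(C)OC21)c1ccccc1` is still unmeasured. It differs from compound 2 by one change: methyl in place of phenyl on a saturated chain carbon bound to an aromatic carbon and a saturated chain carbon. Within the data shown here, no measured pair isolates this change, so the step can only be judged indirectly. Compound 1, which carries no phenyl, stands at 2400000 nM and serves as the upper reference. A modest step towards a higher number is expected in this assay, meaning a weaker inhibitor. The estimate is a 2.2-fold higher number from compound 2 to compound 3 (0.34 log units; beyond the scatter). For compound 3 the expected value is 1100000 nM, with an estimated range of 500000 nM to 2600000 nM.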

Compound 3, half-maximal inhibitory concentration: 500000 nM
Compound 3: middle estimate off by 2.2-fold (0.34 log units), on the high side; measured number inside the range.
By their numbers in this assay, from the lowest: compounds 2 and 3 (each within the scatter of the next); then compound 1.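

In this assay, replacing phenyl with methyl on a saturated chain carbon bound to an aromatic carbon and a saturated chain carbon gives no change at the digits printed from compound 2 to compound 3 (within the scatter), so the second phenyl of compound 2 adds nothing that this read-out can resolve. The step from the small propanoate ester remains with one phenyl in place: 1-phenylethyl in place of methyl on a saturated chain carbon bound to a carbonyl carbon gives a 4.8-fold lower number from compound 1 to compound 3 (0.68 log units; beyond the scatter). Nothing measured here bears on the reason for either step.

Open, from the compounds shown here alone, is whether the remaining phenyl itself carries the step from compound 1, or whether a non-aromatic group such as cyclohexyl would read the same on this carbon. Also open, going by these compounds, is how a longer chain or an amine at this place would read in this assay.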